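Swapping one substituted phenyl group on the shared core

This account rests on a few compounds, and the source may have more. Where it says the series, first, only, none or still open, it means among the compounds named here.

Compound 1 `Nc1nc(NCCNc2ncc(-c3ncc[nH]3)c(-c3cc(F)ccc3F)n2)ccc1[N+](=O)[O-]` gives > 0.5 h as a limit
Compound 2 `Nc1nc(NCCNc2ncc(-c3ncc[nH]3)c(-c3ccc(Br)cc3Cl)n2)ccc1[N+](=O)[O-]` gives > 0.5 h as a limit

In an ADME assay on microsomes from liver (Rattus norvegicus) for metabolic stability (on this read-out lower numbers stand for a shorter-lived compound and higher numbers for a longer-lived compound), compound 2 reads > 0.5 h and this is a limit, not a number. The evidence so far is the limit of > 0.5 h in this assay, at which 2 of the 2 values shown sit, and nothing more. For the measured compounds named here, the only measured step is a step that the two limits leave unreadable from compound 1 to compound 2 and it offers no size to carry over. Compound 3 `Cc1ccc(-c2nc(NCCNc3ccc([N+](=O)[O-])c(N)n3)ncc2-c2ncc[nH]2)c(Br)c1` has 2-bromo-4-methylphenyl in place of 4-bromo-2-chlorophenyl (2-bromo-4-methylphenyl in place of 4-bromo-2-chlorophenyl on an aromatic carbon) on the shared core. With no readable size to go on, no step beyond the scatter is expected, in either direction. The expected change is a step that the limit leaves unreadable from compound 2 to compound 3 on this reasoning. For compound 3 the estimated half-life is 0.8 h with an expected range from 0.4 h to 2 h and the reading may well be only a limit again.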

Compound 3, half-life: > 0.5 h
Compound 3: only a limit was reported (the forecaster's own chance of this, stated with the estimate: 80%); the middle value does not contradict the limit.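

The steps between compound 1, compound 2 and compound 3 cannot be read: each gives only a limit in this assay. Still open, from the compounds shown here alone, is the actual half-life of each compound, and whether swapping the substituted phenyl group changes it at all.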